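The source may report more compounds than this note shows. Statements on the series, on what has been measured and on what is new or still open speak of the compounds shown alone.

Measured so far:
compound 1, `Cc1ccc(S(=O)(=O)c2cnc3ccc(Cl)cc3c2N2CCC(C)CC2)cc1`, gives 95% in an assay on isolated protein for displacement of a labelled ligand from metabotropic glutamate receptor 5 (Homo sapiens), with a stated time of 60 min, tested at 1 uM; a higher number here means more inhibition at the concentration tested (going by the name of the read-out), a lower number less inhibition;
compound 2, `Cc1ccc(S(=O)(=O)c2cnc3ccc(Cl)cc3c2N2CCC(C)CC2)cc1C`, gives 84% in this assay;
compound 3, `Cc1ccc(S(=O)(=O)c2cnc3ccc(F)cc3c2N2CCC(C)CC2)cc1F`, gives 86% in this assay.

All three share one core and differ only in small substituents on two aromatic rings. Compound 3 stands in the middle of the three numbers, yet its gap to compound 2 and its gap to compound 1 both lie within the usual scatter, so none of these three can be told apart with confidence.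

Compound 4, `Cc1ccc(S(=O)(=O)c2cnc3ccc(Cl)cc3c2N2CCC(C)CC2)cc1F`, differs from compound 3 in one place: chloro in place of fluoro on an aromatic carbon. Within the data shown here, the only measured step between compounds that differ in one place is a number 11 percentage points lower from compound 1 to compound 2 (beyond the scatter), and that step concerns a methyl group on a different ring, so it says little about swapping one halogen for another. Compound 1 and compound 3 differ in two places, one of them the same chloro-for-fluoro exchange; their two numbers lie within the scatter of each other. With nothing pointing to a shift beyond the scatter, the expected step of a number 2 percentage points higher from compound 3 to compound 4 (within the scatter) is small, and compound 4 is estimated at 88%, with a range from 78% to 96%.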

Compound 4, a percentage reported as inhibition, at one concentration (the size of the read-out at that concentration, not a potency): 68%
For compound 4 the middle estimate is 20 percentage points above the measured one, and the stated range ends above it.
By their numbers in this assay, from the lowest: compound 4; then compounds 2, 3 and 1 (each within the scatter of the next, the first and the last beyond it).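

Chloro and fluoro are not interchangeable at this position, on an aromatic carbon of the fused ring system: in this assay the exchange gives a number 18 percentage points lower from compound 3 to compound 4 (beyond the scatter), the first single-place comparison of two halogens here. The other aromatic ring is just as sensitive with chloro on the fused system, as placing fluoro on it in place of hydrogen gives a number 27 percentage points lower from compound 1 to compound 4 (beyond the scatter), while fluoro in place of methyl at that same carbon gives a number 16 percentage points lower from compound 2 to compound 4 (beyond the scatter), so among these three compounds the one with hydrogen there stands highest and the one with fluoro lowest. Nothing measured here explains why these small exchanges move the number.

Among these compounds, the halogen exchange has been seen only with fluoro on the other ring, so its size with hydrogen or methyl at that carbon remains unknown. The compounds shown also leave open how a bromo group, a methoxy group or a nitrile would behave at the fused-ring position, and whether a single concentration reflects differences in potency across this series.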